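A few compounds are considered here, and "the series" means these few. Any claim that something is new, unique, unknown or untested is made for them only; others in the source may bear on it.

Measured so far in a functional assay on the whole organism (B cells) with Mus musculus as the target; on this read-out higher numbers stand for larger maximal responses and lower numbers for smaller maximal responses:
compound 1 `C=CCn1c(=O)n(C2C=CC(CO)O2)c2nc(N)nc(O)c21` gives 45%;
compound 2 `Cn1c(=O)n([C@@H]2O[C@H](CO)[C@H]3OC(C)(C)O[C@H]32)c2nc(N)nc(O)c21` gives 193%;
compound 3 `CCCn1c(=O)n(C2OC(COP(=O)(O)O)[C@@H](O)[C@H]2O)c2nc(N)nc(O)c21` gives 76%.

Compound 2 stands highest of these three, beyond the scatter above compound 3 and further still above compound 1. Compound 4 `CC1(C)O[C@@H]2[C@H](O1)[C@@H](CO)O[C@H]2n1c(=O)n(C/C=C/c2ccccc2)c2c(O)nc(N)nc21` is not yet measured. It differs from compound 2 in one place: 2-phenylethenyl in place of hydrogen on a saturated chain carbon bound to an aromatic nitrogen. Cut one bond further out, the same difference reads methyl to 3-phenylprop-2-en-1-yl. For the measured compounds named here, no pair of measured compounds isolates this change; compound 1 and compound 3 carry other chains on that nitrogen but also differ from compound 2 elsewhere, so their lower numbers cannot be tied to the chain alone. Still, a step from compound 2 to compound 4 of a number 83 percentage points lower from compound 2 to compound 4 (beyond the scatter) is expected, downward and beyond the scatter. Compound 4 is estimated at 110%, within a range from 40% to 200%.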

Compound 4, largest response reached (reported as maximal response), in percent of the reference or control that the assay uses: 16%
Estimate against measurement, compound 4: 94 percentage points above; measured number below the stated range.
By their numbers in this assay, from the lowest: compound 4; then compound 1; then compound 3; then compound 2.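

With the rest of the molecule held the same, the chain on this nitrogen clearly matters: in this assay, putting 2-phenylethenyl in place of hydrogen on this saturated chain carbon gives a large fall, a number 177 percentage points lower from compound 2 to compound 4 (beyond the scatter). Earlier compounds could not show this, as they also differed elsewhere. No available evidence bears on the reason for this fall. Still open, as far as these compounds go, is whether the phenyl ring, the double bond or the chain length alone carries it. A 3-phenylpropyl chain or a chain ending in an amine, on the core of compound 2, is not among the compounds shown.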